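The compounds below may be only part of what the source reports. "The series", "measured", "known", "first", "only" and "open" are said of these compounds alone.

Compound 1, `CCOc1ccc(/C=C(/Sc2ccc(C)cc2)C(=O)c2ccc(Cl)cc2)cc1OC`: 25000 nM
Compound 2, `Cc1ccc(CS(=O)(=O)/C(=C/c2c[nH]c3ccccc23)C(=O)c2ccc(Cl)cc2)cc1`: 25000 nM
Compound 3, `O=C(/C(=C\c1ccc(O)c([N+](=O)[O-])c1)Sc1ccccc1Br)c1ccc(Br)cc1`: 10000 nM

In a functional assay on DU-145 cells (Homo sapiens) for inhibition, read by trypan blue exclusion, with a stated time of 96 h (on this read-out higher numbers stand for weaker inhibition of growth and lower numbers for stronger inhibition of growth), compound 2 gives 25000 nM. On this read-out compound 2 stands level with compound 1 at the digits shown, and these two together carry the highest numbers of the three. Compound 3 gives 10000 nM in this assay, a lower number than compound 2 by more than the usual scatter, but compound 3 differs from compound 2 in several places at once, so no single change can be read from that pair.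

Compound 4, `Cc1ccc(CS(=O)(=O)/C(=C/c2cccc(Cl)c2Cl)C(=O)c2ccc(Cl)cc2)cc1`, has not yet been measured in this assay. It differs from compound 2 in one place: 2,3-dichlorophenyl in place of 1H-indol-3-yl on a double-bonded chain carbon bound to a double-bonded chain carbon. Going by the values given here, no measured pair isolates this change, so the expectation rests on the general level of the three numbers. The step from compound 2 to compound 4 is expected to be small, a 1.4-fold lower number from compound 2 to compound 4 (0.14 log units; within the scatter), leaning toward a lower number but not clearly beyond the scatter. Compound 4 is therefore estimated at 18000 nM, within a range of 5000 nM to 50000 nM.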

Compound 4, concentration for 50% growth inhibition: 1000 nM
Compound 4: middle estimate off by 18-fold (1.26 log units), on the high side; measured number below the stated range.
By their numbers in this assay, from the lowest: compound 4; then compound 3; then compounds 1 and 2 (each within the scatter of the next).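

In this assay, putting 2,3-dichlorophenyl in place of 1H-indol-3-yl on a double-bonded chain carbon bound to a double-bonded chain carbon gives a 25-fold lower number from compound 2 to compound 4 (1.40 log units; beyond the scatter). Going by these compounds alone, this position therefore has a strong bearing on the read-out, which the earlier compounds could not show, as no two of them differed in one place only. Nothing available here accounts for the size of this step.

The compounds shown leave open whether the step follows from the arrival of the two chlorine atoms or the departure of 1H-indol-3-yl, a question that an unsubstituted phenyl at this place would help to separate. They also leave open how an amine or a carboxylic acid on the phenyl ring would read in this assay, and whether the same change would give a similar step on another core.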